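The compounds below may be only part of what the source reports. "The series", "measured", "known", "first", "only" and "open" are said of these compounds alone.

Among the compounds with values here, in a functional assay on HeLa cells (Homo sapiens) for antiproliferative activity, read by MTT assay, with a stated time of 48 h (a higher number here means a weaker inhibitor, a lower number a stronger inhibitor), two compounds sharing one core have numbers so far. Compound 1 `C=C(c1cc(OC)c(OC)c(OC)c1)c1ccc(OC)c(O)c1NC(C)=O` gives 90 nM, and compound 2 `C=C(c1cc(OC)c(OC)c(OC)c1)c1ccc(OC)c(O)c1NC(=O)COC` gives 330 nM, the higher of the two numbers and so the weaker inhibitor of this pair. Within the data shown here, compound 3 `C=C(c1cc(OC)c(OC)c(OC)c1)c1ccc(OC)c(O)c1NC(=O)COCC` has no measurement yet. It differs from compound 2 by a single change, methyl in place of hydrogen on a saturated chain carbon bound to an oxygen on a saturated carbon, so that methoxy becomes ethoxy. Among the measured compounds shown here, only one measured step bears on this change, namely a 3.7-fold higher number from compound 1 to compound 2 (0.56 log units; beyond the scatter), which came with methoxy in place of hydrogen on a saturated chain carbon bound to a carbonyl carbon. That is a modest step and a different change, made on the same chain, so it offers only a rough guide. It does suggest that growing this chain further may raise the number again, though by less, since only one carbon is added. The expected step is a 1.5-fold higher number from compound 2 to compound 3 (0.16 log units; within the scatter), which could prove hard to tell from the scatter. Compound 3 is estimated at 480 nM, with an expected range from 200 nM to 1200 nM.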

Compound 3, half-maximal inhibitory concentration: 690 nM
Compound 3: the middle estimate sits 1.4-fold (0.16 log units) below what was measured, and the stated range covers the measured number.
By their numbers in this assay, from the lowest: compound 1; then compound 2; then compound 3.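

In this assay, turning methoxy into ethoxy gives a 2.1-fold higher number from compound 2 to compound 3 (0.32 log units; beyond the scatter), so a single methyl on a saturated chain carbon bound to an oxygen on a saturated carbon is enough to produce a change beyond the usual scatter. Taken with the earlier step, each addition to this chain has now raised the number, with none of the three compounds going against that trend, and replacing hydrogen with ethoxy amounts overall to a 7.7-fold higher number from compound 1 to compound 3 (0.88 log units; beyond the scatter), leaving compound 3 the weakest inhibitor of the three and compound 1 the strongest. No measurement at hand explains why the number rises along this short series.

The compounds shown leave open whether a longer chain, such as propoxy or butoxy, would keep raising the number or whether the rise would level off. They also leave open whether chain length alone tracks with the change, a question that a hydroxyl, an amine or a cyclopropyl group at this place could help to test.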